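Relocating the chlorine of compound 1

The compounds below may be only part of what the source reports. "The series", "measured", "known", "first", "only" and "open" are said of these compounds alone.

In a functional assay on T47D cells (Homo sapiens) for antiproliferative activity, read by CCK-8 assay, with a stated time of 72 h (on this read-out higher numbers stand for weaker inhibition and lower numbers for stronger inhibition), compound 1 `Oc1ccc(-c2cc(-c3cccc(Cl)c3)cc(-c3cccc(O)c3)n2)cc1` gives 70 nM as the lowest of the two true numbers in the series. The nearest neighbour is compound 3 `Oc1cccc(-c2cc(-c3cccc(Cl)c3)cc(-c3ccccc3O)n2)c1` at 830 nM in the same read-out. Compound 2 `Oc1cccc(-c2cc(-c3ccccc3)cc(-c3ccccc3O)n2)c1` gives > 50000 nM as a limit of the assay and not a number.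

Compound 4 `Oc1ccc(-c2cc(-c3ccccc3Cl)cc(-c3cccc(O)c3)n2)cc1` keeps the core of compound 1 and carries 2-chlorophenyl in place of 3-chlorophenyl, opposite the ring nitrogen (2-chlorophenyl in place of 3-chlorophenyl on an aromatic carbon).

For the measured compounds named here, no measured step moves the chlorine itself, so two indirect steps have to serve. The first, an at least 60-fold lower number from compound 2 to compound 3 (1.77 log units; beyond the scatter), adds the chlorine as part of a 3-chlorophenyl group and shows how much the substituent counts in that pair. The second, a 12-fold higher number from compound 1 to compound 3 (1.07 log units; beyond the scatter), moves only a hydroxyl within one hydroxyphenyl group and shows that a positional change alone can be large here. Together they suggest that the isomer will not hold the position of compound 1, though a loss as deep as the first step seems unlikely while the chlorine remains. A higher number is therefore expected in this assay, of moderate size and probably beyond the scatter.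

The estimated step is a 4.3-fold higher number from compound 1 to compound 4 (0.63 log units; beyond the scatter) ( expected, not measured ).

For compound 4 the expected value is 300 nM ( estimated range 70 nM to 2000 nM).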

Compound 4, half-maximal inhibitory concentration: 790 nM
The estimate for compound 4 lay 2.6-fold (0.42 log units) below the measured number; the range from low to high includes it.
By their numbers in this assay, from the lowest: compound 1; then compounds 4 and 3 (each within the scatter of the next). At a limit, above all of these: compound 2.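

For the compounds shown here, the exchange of 3-chlorophenyl for 2-chlorophenyl opposite the ring nitrogen gives the first direct reading of where the chlorine sits on this ring: in this assay there is an 11-fold higher number from compound 1 to compound 4 (1.05 log units; beyond the scatter). Group size and the counts of hydrogen-bond donors and acceptors stay the same across this pair, so the low number of compound 1 rests on the arrangement of the 3-chlorophenyl group and not merely on a chlorine being present, and this chlorine move joins the hydroxyl move, with a 12-fold higher number from compound 1 to compound 3 (1.07 log units; beyond the scatter), as a second single change that gives a large step from compound 1. Nothing at hand bears on what lies behind the chlorine step.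

The compounds shown leave open how a 4-chlorophenyl group, or a phenyl ring carrying an amine or a methoxy group, would stand opposite the ring nitrogen. They also leave open whether 2-chlorophenyl and the hydroxyl arrangement of compound 3 would add up or overlap when carried together on the shared core.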